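The source may hold more compounds than are shown below. What is called first, only, known or untested is meant among the compounds shown, and "the series" means these compounds.

In an assay for inhibition of Amine oxidase [flavin-containing] B (Homo sapiens), read by fluorescence, using microsomes, with a stated time of 30 min (a higher number here means a weaker inhibitor, a lower number a stronger inhibitor), compound 3 `Cc1c(C)c2ccc(OCC3CCN(Cc4cccc(CO[N+](=O)[O-])c4)CC3)cc2oc1=O` gives 51 nM, the lowest of the three numbers measured. Compound 1 `Cc1c(C)c2ccc(OCC3CCN(Cc4cccc(CO)c4)CC3)cc2oc1=O` gives 76 nM and compound 2 `Cc1c(C)c2ccc(OCC3CCN(Cc4cccc(OCCCO)c4)CC3)cc2oc1=O` gives 780 nM; the steps were a 1.5-fold lower number from compound 1 to compound 3 (0.17 log units; within the scatter) and a 15-fold lower number from compound 2 to compound 3 (1.18 log units; beyond the scatter). Compound 4 `Cc1c(C)c2ccc(OCC3CCN(CCCO[N+](=O)[O-])CC3)cc2oc1=O` has not yet been measured; it carries 2-(nitrooxy)ethyl in place of 3-((nitrooxy)methyl)phenyl on a saturated chain carbon bound to an amine nitrogen in a ring. Only loosely related steps exist: a 1.5-fold lower number from compound 1 to compound 3 (0.17 log units; within the scatter) shows that adding the nitro group barely moved the number, whereas a 10-fold higher number from compound 1 to compound 2 (1.01 log units; beyond the scatter) shows that changing the group carried on the aromatic ring can shift it a long way. Among the compounds with values here, no measured step removes that ring, so compound 4 is expected to show a moderately higher number in this assay, as a 5.9-fold higher number from compound 3 to compound 4 (0.77 log units; beyond the scatter). Compound 4 is therefore estimated at 300 nM, within 60 nM to 1500 nM.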

Compound 4, half-maximal inhibitory concentration: 250 nM
Compound 4: the middle estimate sits 1.2-fold (0.08 log units) above what was measured; the measured number falls inside the stated range.
By their numbers in this assay, from the lowest: compounds 3 and 1 (each within the scatter of the next); then compound 4; then compound 2.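

In this assay, the aromatic ring at this place is not needed for inhibition, although swapping 3-((nitrooxy)methyl)phenyl for 2-(nitrooxy)ethyl does weaken it (a 4.9-fold higher number from compound 3 to compound 4 (0.69 log units; beyond the scatter)). The ring alone does not set the number: the ring-free compound is weaker than one ring-bearing compound (a 3.3-fold higher number from compound 1 to compound 4 (0.52 log units; beyond the scatter)) but stronger than another (a 3.1-fold lower number from compound 2 to compound 4 (0.49 log units; beyond the scatter)), so compound 2 goes against any simple ring advantage. Nothing shown here explains these shifts.

Still open, on these data alone, is how a 2-hydroxyethyl group, carrying a hydroxyl instead of the nitrooxy group, would compare with compound 4. A longer chain ending in nitrooxy also remains untested among these compounds.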